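Phenyl in Place of Methyl on a Saturated Ring Carbon

A few compounds are considered here, and "the series" means these few. Any claim that something is new, unique, unknown or untested is made for them only; others in the source may bear on it.

Compound 1, `Cc1cccc(S(=O)(=O)NCCNC(=N)N2CCC(C)CC2)c1`, gives 177 nM in an assay on HEK293 cells for binding affinity to 5-hydroxytryptamine receptor 7 (Homo sapiens); on this read-out lower numbers stand for stronger inhibition and higher numbers for weaker inhibition.
Compound 2, `Cc1cccc(S(=O)(=O)NCCCNC(=N)N2CCC(c3ccccc3)CC2)c1`, gives 276 nM in this assay.

Only these two compounds have been measured, and their values lie within the usual scatter of each other, so neither can be called the stronger binder. Going by the values given here, compound 1 and compound 2 differ in more than one place, so no single structural step links them. Compound 3, `Cc1cccc(S(=O)(=O)NCCNC(=N)N2CCC(c3ccccc3)CC2)c1`, has not yet been measured. It arises from compound 1 by one change: phenyl in place of methyl on a saturated ring carbon. Compound 2 already carries a phenyl group on that same ring carbon, together with a longer chain, and its number sits close to that of compound 1. On this basis the phenyl group alone is not expected to shift the result beyond the scatter in this assay. The step from compound 1 to compound 3 is therefore estimated as a 1.1-fold higher number from compound 1 to compound 3 (0.05 log units; within the scatter). Compound 3 is expected to give about 200 nM, with a range from 80 nM to 500 nM.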

Compound 3, inhibition constant: 161 nM
The estimate for compound 3 lay 1.2-fold (0.09 log units) above the measured number; low and high end bracket the measured number.
By their numbers in this assay, from the lowest: compounds 3, 1 and 2 (each within the scatter of the next).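

Swapping methyl for phenyl on this saturated ring carbon, with the rest of the molecule unchanged, gives a 1.1-fold lower number from compound 1 to compound 3 (0.04 log units; within the scatter) in this assay. Compound 1 and compound 2 differ in more than one place, so they could not isolate this change; this pair does, and it shows that one six-membered aromatic ring of carbon only can stand where a single carbon stood without a change in the number that exceeds the scatter. No available measurement bears on the reason for this result.

Methyl and phenyl both count no hydrogen-bond donors and no hydrogen-bond acceptors, so the compounds shown leave open how an amine or a carboxylic acid on the same ring carbon would compare in this assay. They also leave open whether this position would accept a still larger group, such as a benzyl group, or a phenyl ring that itself carries a chlorine atom or a methoxy group.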